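This account rests on a few compounds, and the source may have more. Where it says the series, first, only, none or still open, it means among the compounds named here.

Measured in an assay for inhibition of inositol hexakisphosphate kinase 2 (Homo sapiens), read by colorimetric assay, coupled enzyme assay and malachite green, with a stated time of 120 min, in the presence of a further agent that is not named here; on this read-out higher numbers stand for weaker inhibition and lower numbers for stronger inhibition:
Compound 1 `COC(=O)/C=C/c1ccc2noc(-c3ccccc3)c2c1` gives 1580 nM
Compound 2 `CN(C)C(=O)/C=C/c1ccc2noc(-c3ccccc3)c2c1` gives 40300 nM
Compound 3 `Cc1ccc(-c2onc3ccc(/C=C/C(=O)O)cc23)cc1` gives 6510 nM

Compound 3 stands second highest of the three numbers in this assay: compound 1 gives a lower number and compound 2 a higher one, both beyond the scatter. Compound 4 `O=C(O)/C=C/c1ccc2noc(-c3ccc(OC(F)(F)F)cc3)c2c1` differs from compound 3 by trifluoromethoxy in place of methyl on an aromatic carbon. Among the measured compounds shown here, the only step measured so far, a 26-fold higher number from compound 1 to compound 2 (1.41 log units; beyond the scatter), concerns the group on the carbonyl carbon and not the aromatic ring, so it does not bear on this change. For the measured compounds named here, no measured pair alters the ring substituent, and nothing in these data points to a direction. The expected step is therefore a 1.1-fold lower number from compound 3 to compound 4 (0.04 log units; within the scatter), within the scatter, though with wide uncertainty. The estimate for compound 4 in this assay is 6000 nM, between 1500 nM and 25000 nM.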

Compound 4, half-maximal inhibitory concentration: 320 nM
For compound 4 the middle estimate is 19-fold (1.27 log units) above the measured one, outside the stated range (below it).
By their numbers in this assay, from the lowest: compound 4; then compound 1; then compound 3; then compound 2.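

In this assay, the substituent on the aromatic ring proves to matter. With the carboxylic acid end held fixed, trifluoromethoxy in place of methyl, para to a large group, gives a 20-fold lower number from compound 3 to compound 4 (1.31 log units; beyond the scatter) and so shows a large step at a place the earlier step, confined to the group on the carbonyl carbon, did not touch. Nothing given here accounts for this step.

The compounds shown leave open whether methoxy, chlorine or trifluoromethyl at this place would give a similar step. They also leave open whether it would persist with a methyl ester in place of the carboxylic acid.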